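Trimming a methoxyethyl amide back to methyl

The source may hold more compounds than are shown below. What is called first, only, known or untested is meant among the compounds shown, and "the series" means these compounds.

Of the compounds shown here, two with a shared core have been measured in a physicochemical assay for lipophilicity; on this read-out lower numbers stand for lower lipophilicity and higher numbers for higher lipophilicity. Compound 1 `Cc1nc2c(O[C@H]3c4ccccc4C[C@@H]3O)cc(C(=O)N(C)C)cn2c1C` gives 2.2. Compound 2 `COCCNC(=O)c1cc(N[C@H]2c3ccccc3C[C@@H]2O)c2nc(C)c(C)n2c1` gives 3.43, the higher of the two numbers, standing a gap beyond the usual scatter above compound 1. Among the measured compounds shown here, the two differ in more than one place, so no single structural step between them can be read off.

Compound 3 `CNC(=O)c1cc(N[C@H]2c3ccccc3C[C@@H]2O)c2nc(C)c(C)n2c1` has not yet been measured in this assay. It differs from compound 2 in one place: hydrogen in place of methoxymethyl on a saturated chain carbon bound to an amide-type nitrogen. Put another way, a 2-methoxyethyl group on the amide nitrogen becomes a methyl group.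

For the measured compounds named here, since no measured pair shows exactly this change, the size of the step can only be guessed. Removing three heavy atoms from a chain would usually be expected to lower the number somewhat, and the expected change from compound 2 to compound 3 is a number 0.33 log units lower from compound 2 to compound 3 (beyond the scatter), a step close to the edge of the usual scatter. Compound 3 is therefore estimated at 3.1, most likely between 2.6 and 3.6.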

Compound 3, partition coefficient: 3.4
Compound 3: the middle estimate sits 0.30 log units below what was measured, within the range that was stated.
By their numbers in this assay, from the lowest: compound 1; then compounds 3 and 2 (each within the scatter of the next).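

In this assay, going from (2-methoxyethyl)carbamoyl to methylcarbamoyl gives a number 0.03 log units lower from compound 2 to compound 3 (within the scatter), so this step does not separate the two compounds on this read-out. Among the compounds shown here, this is the first single-place comparison, and it shows that, on a saturated chain carbon bound to an amide-type nitrogen, methoxymethyl and hydrogen give values that cannot be told apart, even though the methoxymethyl group carries 3 heavy atoms and 1 hydrogen-bond acceptor that hydrogen lacks. No measurement shown here accounts for this result.

From the compounds shown here alone, a single pair gives one step at one place, so it remains open whether other groups at this position would also leave the number within the scatter: for example a longer chain such as n-butyl, or a chain ending in an amine or a carboxylic acid. Going by these compounds, it is also open whether the same change from 2-methoxyethyl to methyl would give a similar step on a compound that differs elsewhere in the shared core.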